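Isopropylamino in Place of Hydroxypropylamino: What to Expect

This account rests on a few compounds, and the source may have more. Where it says the series, first, only, none or still open, it means among the compounds named here.

Compound 1 `O=C(Nc1ccc(Oc2cc(O)ncn2)cc1)Nc1cccc(C(F)(F)F)c1`: in an assay on isolated protein for inhibition of serine/threonine-protein kinase TNNI3K (Homo sapiens) (on this read-out higher numbers stand for weaker inhibition and lower numbers for stronger inhibition), compound 1 gives 3200 nM.
Compound 2 `CCCNc1cc(Oc2ccc(NC(=O)Nc3cccc(C(F)(F)F)c3)cc2)ncn1`: in this assay compound 2 gives 32 nM.
Compound 3 `C[C@@H](O)CNc1cc(Oc2ccc(NC(=O)Nc3cccc(C(F)(F)F)c3)cc2)ncn1`: in this assay compound 3 gives 63 nM.

All three share the same core and differ only in the group on one aromatic carbon. On the numbers shown, the step of a 51-fold lower number from compound 1 to compound 3 (1.71 log units; beyond the scatter) is large, while the step of a 2.0-fold higher number from compound 2 to compound 3 (0.29 log units; within the scatter) lies within the scatter, so no order can be set between compound 2 and compound 3.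

Compound 4 `CC(C)Nc1cc(Oc2ccc(NC(=O)Nc3cccc(C(F)(F)F)c3)cc2)ncn1` has not yet been measured in this assay. It differs from compound 3 in one place: isopropyl in place of 2-hydroxypropyl on a nitrogen on an aromatic ring.

Two kinds of measured step bear on this. The steps of a 100-fold lower number from compound 1 to compound 2 (2.00 log units; beyond the scatter) and a 51-fold lower number from compound 1 to compound 3 (1.71 log units; beyond the scatter) show that an alkylamino group in place of hydroxy brings a large gain, and compound 4 keeps such a group. The step of a 2.0-fold higher number from compound 2 to compound 3 (0.29 log units; within the scatter) shows that adding a hydroxy to the chain changes nothing beyond the scatter, so taking it away is expected to change nothing beyond the scatter either.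

Compound 4 is therefore expected to give 40 nM in this assay, with a range from 15 nM to 120 nM. The expected step is a 1.6-fold lower number from compound 3 to compound 4 (0.20 log units; within the scatter).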

Compound 4, half-maximal inhibitory concentration: 40 nM
Compound 4: middle estimate and measured number agree at the digits printed; the measured number falls inside the stated range.
By their numbers in this assay, from the lowest: compounds 2, 4 and 3 (each within the scatter of the next); then compound 1.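

In this assay, the nitrogen on the aromatic ring takes isopropyl in place of 2-hydroxypropyl (a 1.6-fold lower number from compound 3 to compound 4 (0.20 log units; within the scatter)) and in place of propyl (a 1.3-fold higher number from compound 2 to compound 4 (0.10 log units; within the scatter)) with both steps within the scatter, so the loss of the hydroxy, with its hydrogen-bond donor and acceptor and the defined stereocentre, and the difference between a branched and a straight chain produce no readable change here. The large step against the hydroxy compound (an 80-fold lower number from compound 1 to compound 4 (1.90 log units; beyond the scatter)) adds a branched group to the straight and hydroxylated ones, so all three alkylamino groups shown bring a large gain over hydroxy and stay within the scatter of each other. Nothing shown offers an explanation for why these three groups cannot be told apart.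

Going by these compounds, the three groups are all small, so it remains open whether a longer chain such as hexyl, a ring such as cyclopropyl or cyclohexyl, or a dimethylamino group would stay in the same range. On these data alone, the other stereoisomer of the 2-hydroxypropyl group also remains open.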